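Neopentyl for pyridin-4-yl: cytotoxicity limit notes

This account rests on a few compounds, and the source may have more. Where it says the series, first, only, none or still open, it means among the compounds named here.

In an ADME assay on 2209-23 cells (Homo sapiens) for cytotoxicity, read by WST assay (a higher number here means that more compound is tolerated, a lower number that less compound is tolerated), compound 1 (`CS(=O)(=O)Nc1ccc2c(c1)S(=O)(=O)C=C(c1c(O)c3cc(F)ccc3n(Cc3ccccc3)c1=O)N2`) gives > 50000 nM as a limit of the assay. Compound 2 (`CS(=O)(=O)Nc1ccc2c(c1)S(=O)(=O)C=C(c1c(O)c3cc(F)ccc3n(Cc3ccncc3)c1=O)N2`) gives > 50000 nM as a limit too, so it stands without a number. Going by the values given here, the series so far shows the limit of > 50000 nM in this assay, at which 2 of the 2 values shown sit, and nothing else. Compound 3 (`CC(C)(C)CCn1c(=O)c(C2=CS(=O)(=O)c3cc(NS(C)(=O)=O)ccc3N2)c(O)c2cc(F)ccc21`) carries neopentyl in place of pyridin-4-yl on a saturated chain carbon bound to an aromatic nitrogen. Among the compounds with values here, the one measured step is a step that the two limits leave unreadable from compound 1 to compound 2 and offers no size to carry over. The expected result is a number no higher from compound 2 to compound 3 (the limit leaves the size open) with nothing beyond the scatter expected in this assay here. Compound 3 is expected at 50000 nM (estimated range 20000 nM to 50000 nM).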

Compound 3, half-maximal cytotoxic concentration: > 50000 nM
Compound 3: only a limit was reported; the forecaster's own chance of this, stated with the estimate: 75%; the middle value sits exactly at the limit.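

No step among compound 1, compound 2 and compound 3 can be read, as each stands only at a limit of the assay: the limit of > 50000 nM in this assay, at which 3 of the 3 values shown sit.

Left open is the actual half-maximal cytotoxic concentration of each of these compounds, and whether phenyl, pyridin-4-yl or neopentyl makes any difference to it.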